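This account rests on a few compounds, and the source may have more. Where it says the series, first, only, none or still open, it means among the compounds named here.

Within the data shown here, in an assay on SK-BR-3 cells for inhibition of Aromatase (Homo sapiens) (a higher number here means a weaker inhibitor, a lower number a stronger inhibitor), compound 2 `CN(c1ccc(NC(=O)C2CCCCC2)cc1OCc1ccccc1)S(C)(=O)=O` gives 250 nM, the lowest of the two numbers measured so far. Among the measured compounds shown here, its only neighbour, compound 1 `CN(c1ccc(NC(=O)c2ccccc2)cc1OCc1ccccc1)S(C)(=O)=O`, gives 1770 nM in this assay, and the single measured step, a 7.1-fold lower number from compound 1 to compound 2 (0.85 log units; beyond the scatter), is the only guide for this series. Compound 3 `CN(c1ccc(NC(=O)c2ccc(Cl)c([N+](=O)[O-])c2)cc1OCc1ccccc1)S(C)(=O)=O` differs from compound 2 by 4-chloro-3-nitrophenyl in place of cyclohexyl on a carbonyl carbon. For the measured compounds named here, since the one step that bears on it, a 7.1-fold lower number from compound 1 to compound 2 (0.85 log units; beyond the scatter), ran downward when an aromatic ring left the carbonyl carbon, the return of an aromatic ring is expected to move this assay back upward, by roughly a 4.8-fold higher number from compound 2 to compound 3 (0.68 log units; beyond the scatter). Compound 3 is therefore estimated at 1200 nM, with a range from 300 nM to 5000 nM.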

Compound 3, half-maximal inhibitory concentration: 690 nM
Compound 3: the middle estimate sits 1.7-fold (0.24 log units) above what was measured; the range from low to high includes it.
By their numbers in this assay, from the lowest: compound 2; then compound 3; then compound 1.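

In this assay, 4-chloro-3-nitrophenyl in place of phenyl on a carbonyl carbon gives a 2.6-fold lower number from compound 1 to compound 3 (0.41 log units; beyond the scatter) so the aromatic ring at this place tolerates substitution with a gain. That gain does not close the gap to the saturated ring, as a 2.8-fold higher number from compound 2 to compound 3 (0.44 log units; beyond the scatter) leaves cyclohexyl with the lowest number of the three. Open, going by these compounds, is whether chloro or nitro alone carries the step from phenyl, since the two enter together. Also open, on these data alone, is how a piperidine ring or a straight hexyl chain on the carbonyl carbon would compare with cyclohexyl. Nothing available explains these steps.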